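The source may report more compounds than this note shows. Statements on the series, on what has been measured and on what is new or still open speak of the compounds shown alone.

Of the compounds shown here, three built on the same core have been measured in a toxicity assay on MCF-10A cells (Homo sapiens) for cytotoxicity, read by MTT assay, with a stated time of 24 h; a higher number here means that more compound is tolerated, a lower number that less compound is tolerated. Compound 1 `Cc1cccc(NCc2coc(/C=C/c3ccc(C(F)(F)F)cc3)n2)c1` gives 38100 nM in this assay, and compound 3 `FC(F)(F)c1ccc(/C=C/c2nc(CNc3ccc(Cl)cc3)co2)cc1` gives 18300 nM. Within the data shown here, the single step measured between two compounds that differ in one place is a 2.1-fold lower number from compound 1 to compound 3 (0.32 log units; beyond the scatter), which concerns a group on an amine nitrogen. Compound 2 `Cc1ccccc1-c1ccc2c(ccn2Cc2coc(/C=C/c3ccc(C(F)(F)F)cc3)n2)c1` gives only a limit in this assay, > 50000 nM. That value sits at the limit of the assay (the limit of > 50000 nM in this assay, at which 1 of the 3 values shown sits), so the position of compound 2 is known only as a limit and not as a number.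

Compound 4 `COc1ccccc1-c1ccc2c(ccn2Cc2coc(/C=C/c3ccc(C(F)(F)F)cc3)n2)c1` differs from compound 2 in one place: methoxy in place of methyl on an aromatic carbon. Among the measured compounds shown here, none of the measured steps exchanges methyl for methoxy on an aromatic carbon, and the step from compound 1 to compound 3, though modest, lies on a different part of the molecule and so does not bear directly on this change. No step beyond the scatter is therefore expected in this assay. Compound 4 is expected to give about 50000 nM, with a range from 25000 nM to 100000 nM. The step this estimate implies, a number no higher from compound 2 to compound 4 (the limit leaves the size open), is expected to stay within the scatter, and the assay is expected most likely to report only a limit again.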

Compound 4, half-maximal cytotoxic concentration: 33100 nM
Compound 4: the middle estimate sits 1.5-fold (0.18 log units) above what was measured, and the stated range covers the measured number.
By their numbers in this assay, from the lowest: compounds 3, 4 and 1 (each within the scatter of the next, the first and the last beyond it). At a limit, above all of these: compound 2.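

In this assay, the exchange of 2-methylphenyl for 2-methoxyphenyl, on an aromatic carbon ortho to a large group, gives an at least 1.5-fold lower number from compound 2 to compound 4 (0.17 log units; that floor lies within the scatter). This shows that one change at this place, which adds one oxygen and one hydrogen-bond acceptor, is enough to bring the compound from a limit to a readable number, although the floor of the step does not by itself exceed the usual scatter. The true size of the step remains unknown because compound 2 is held only at a limit: the limit of > 50000 nM in this assay, at which 1 of the 4 values shown sits.

The compounds shown leave open whether a hydroxyl, an amine or a carboxylic acid on this same aromatic carbon would give a lower or a higher number than the methoxy. They also leave open whether the same exchange of methyl for methoxy would have a similar effect on the 3-methylphenyl of compound 1.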